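Carbamate series: tert-butyl to benzyl on the ester oxygen

The source may report more compounds than this note shows. Statements on the series, on what has been measured and on what is new or still open speak of the compounds shown alone.

Compound 1 `CCCCOC(=O)CNC(=O)[C@H](CSc1ccc([N+](=O)[O-])cc1[N+](=O)[O-])NC(=O)CC[C@H](Nc1ccc([N+](=O)[O-])cc1[N+](=O)[O-])C(=O)OCCCC`: in a toxicity assay on KB cells (Homo sapiens) for cytotoxicity, read by fluorescence, with a stated time of 3 days (a higher number here means that more compound is needed for the effect, a lower number that less compound is needed), compound 1 gives > 300 uM, a limit of the assay.
Compound 2 `CCCCOC(=O)CNC(=O)[C@H](CSc1ccc([N+](=O)[O-])cc1[N+](=O)[O-])NC(=O)CC[C@H](NC(=O)OC(C)(C)C)C(=O)OCCCC`: in this assay compound 2 gives 70.4 uM.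
Compound 3 `CCCCOC(=O)CNC(=O)[C@H](CSc1ccc([N+](=O)[O-])cc1[N+](=O)[O-])NC(=O)CC[C@H](NC(=O)OC)C(=O)OCCCC`: in this assay compound 3 gives > 300 uM, a limit of the assay.

Compound 2 stands alone as the only number shown in this assay; the other two values sit at a limit (the limit of > 300 uM in this assay, at which 2 of the 3 values shown sit). The step of an at least 4.2-fold lower number from compound 1 to compound 2 (0.62 log units; beyond the scatter) brings the series into readable range, and an at least 4.2-fold higher number from compound 2 to compound 3 (0.62 log units; beyond the scatter) takes it back out. The step that the two limits leave unreadable from compound 1 to compound 3 between the two limits cannot be read.

Compound 4 `CCCCOC(=O)CNC(=O)[C@H](CSc1ccc([N+](=O)[O-])cc1[N+](=O)[O-])NC(=O)CC[C@H](NC(=O)OCc1ccccc1)C(=O)OCCCC` differs from compound 2 by benzyl in place of tert-butyl on an oxygen next to a carbonyl group. Within the data shown here, the one measured change at this oxygen, an at least 4.2-fold higher number from compound 2 to compound 3 (0.62 log units; beyond the scatter), moved the number to the limit; no measured step goes from tert-butyl to a larger group, so no step bears directly on the change toward benzyl. The expectation therefore rests on compound 2 and its step of an at least 4.2-fold higher number from compound 2 to compound 3 (0.62 log units; beyond the scatter) alone, and a step of a 1.6-fold higher number from compound 2 to compound 4 (0.19 log units; within the scatter) is expected, with a real chance that only a limit is reported. Compound 4 is estimated at 110 uM in this assay, within 35 uM to 300 uM.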

Compound 4, concentration for half-maximal effect: 95.2 uM
For compound 4 the middle estimate is 1.2-fold (0.06 log units) above the measured one; measured number inside the range.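

At the oxygen next to a carbonyl group, benzyl and tert-butyl cannot be told apart in this assay, with a 1.4-fold higher number from compound 2 to compound 4 (0.13 log units; within the scatter), so this position now holds two readable numbers and benzyl does not return the series to the limit. Methyl stands alone among the three groups shown here, since an at least 3.1-fold lower number from compound 3 to compound 4 (0.49 log units; beyond the scatter) mirrors an at least 4.2-fold higher number from compound 2 to compound 3 (0.62 log units; beyond the scatter), and the readable range at this oxygen therefore holds for both tert-butyl and benzyl but not for methyl. On the amine nitrogen, an at least 3.1-fold lower number from compound 1 to compound 4 (0.49 log units; beyond the scatter) repeats the direction of an at least 4.2-fold lower number from compound 1 to compound 2 (0.62 log units; beyond the scatter), and both steps, like the one from methyl, start from a limit and not from a number: the limit of > 300 uM in this assay, at which 2 of the 4 values shown sit.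

The compounds shown leave open where between methyl and tert-butyl the number enters readable range, as an ethyl or isopropyl group on this oxygen would show, and whether a free amine on the same nitrogen reads like the carbamates. From the compounds shown here alone, they also leave open how far compound 1 and compound 3 lie past their limit, so the full size of these steps stays unknown.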